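The source may hold more compounds than are shown below. What is called first, only, known or untested is meant among the compounds shown, and "the series" means these compounds.

Working notes on the diarylacetylene hydroxamate series.

Compound 1 `O=C(N[C@H](CO)C(=O)NO)c1ccc(C#Cc2ccccc2)cc1` is the anchor here. Among the compounds with values here, in a physicochemical assay for solubility (a lower number here means a less soluble compound, a higher number a more soluble compound), compound 1 gives 36000 nM, and this is the only number reported in the set. Compound 2 `O=C(NC1(C(=O)NO)CCN(Cc2ccccc2)CC1)c1ccc(C#Cc2ccccc2)cc1` is reported in this assay as a limit of the assay, < 1000 nM, not as a measured number; the set thus shows (the limit of < 1000 nM in this assay, at which 1 of the 2 values shown sits).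

Compound 3 `CC(C)C(NC(=O)c1ccc(C#Cc2ccccc2)cc1)C(=O)NO` is not yet measured. Relative to compound 1 it carries a group of 8 heavy atoms (5 carbon, 1 nitrogen, 2 oxygen; no ring) in place of a group of 7 heavy atoms (3 carbon, 1 nitrogen, 3 oxygen; no ring), on an amide-type nitrogen.

Within the data shown here, no step between two measured compounds is available, so the expected size of the change from compound 1 to compound 3 in this assay rests on the structural change alone. A step beyond the scatter, towards the less soluble end, is expected, estimated as a 3.0-fold lower number from compound 1 to compound 3 (0.48 log units; beyond the scatter). Compound 3 is expected to give 12000 nM in this assay, within a range of 3000 nM to 36000 nM.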

Compound 3, solubility: 7000 nM
Compound 3: middle estimate off by 1.7-fold (0.23 log units), on the high side; the measured number falls inside the stated range.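

Working from the one readable step in the series, the group on the amide-type nitrogen clearly matters in this assay: placing 1-(hydroxycarbamoyl)-2-methylpropyl there gives a 5.1-fold lower number from compound 1 to compound 3 (0.71 log units; beyond the scatter). This single change replaces a group of 7 heavy atoms, with 3 hydrogen-bond donors, 3 hydrogen-bond acceptors and 1 defined stereocentre, by one of 8 heavy atoms, with 2 hydrogen-bond donors and 2 hydrogen-bond acceptors, so these differences travel together and cannot be separated here. Compound 2 remains a limit of the assay, not a number: the limit of < 1000 nM in this assay, at which 1 of the 3 values shown sits.

From the compounds shown here alone, how a 1-(hydroxycarbamoyl) group carrying an amine or a carboxylic acid on its side chain would read in this assay stays open. A longer carbon chain at the same place would also be needed to tell whether the step follows the heavy-atom count or the donor and acceptor counts.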